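The source may report more compounds than this note shows. Statements on the series, on what has been measured and on what is new or still open speak of the compounds shown alone.

Working notes on the series. The reference point is compound 3, `CNC[C@H]1CN(c2ccn(C)c2)C(=O)O1`, which in an assay for inhibition of Amine oxidase [flavin-containing] A (Bos taurus), read by fluorescence, with a stated time of 30 min (a higher number here means a weaker inhibitor, a lower number a stronger inhibitor), gives 7 nM. Among the compounds with values here, compound 3 stands lowest of the three numbers measured so far; its nearest neighbour is compound 2, `Cn1ccc(N2C[C@H](CN=[N+]=[N-])OC2=O)c1`, which in this assay gives 200 nM, and the furthest is compound 1, `C=CCn1ccc(N2C[C@H](CO)OC2=O)c1`, which in this assay gives 350 nM. Within the data shown here, the only step between compounds that differ in a single place is a 29-fold lower number from compound 2 to compound 3 (1.46 log units; beyond the scatter), methylamino in place of azido on a saturated chain carbon bound to a saturated ring carbon.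

Compound 4, `C=CCn1ccc(N2C[C@H](CNC)OC2=O)c1`, differs from compound 3 by vinyl in place of hydrogen on a saturated chain carbon bound to an aromatic nitrogen; cut one bond further out, the change reads methyl to allyl. Among the measured compounds shown here, no measured step bears directly on this change. Compound 1 carries the allyl group, but it differs from compound 2 in a second place as well, so the two values of compound 1 and compound 2 show only that both sit far above compound 3 and do not isolate the methyl-to-allyl change. For the measured compounds named here, the one large step measured concerns a different place. The change at the aromatic nitrogen is therefore expected to be small, within the scatter or a modest weakening, an expected step of a 1.7-fold higher number from compound 3 to compound 4 (0.23 log units; within the scatter). Compound 4 is expected to give an estimated 12 nM in this assay, within a range of 4 nM to 40 nM.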

Compound 4, inhibition constant: 100 nM
Estimate against measurement, compound 4: 8.3-fold (0.92 log units) below, outside the stated range (above it).
By their numbers in this assay, from the lowest: compound 3; then compounds 4, 2 and 1 (each within the scatter of the next, the first and the last beyond it).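

Vinyl in place of hydrogen on a saturated chain carbon bound to an aromatic nitrogen, methyl to allyl when cut one bond further out, gives in this assay a 14-fold higher number from compound 3 to compound 4 (1.15 log units; beyond the scatter) and is the first direct reading of this place, which shows that the group on the aromatic nitrogen is not a silent part of the series. With allyl held fixed, going from hydroxy to methylamino on the chain gives a 3.5-fold lower number from compound 1 to compound 4 (0.54 log units; beyond the scatter) as a modest step, so the group on the chain still counts when allyl is present, though compound 4 does not regain the number of compound 3. No supporting measurement accompanies these results to account for either step.

Only methyl and allyl are shown at this place, so the compounds leave open whether the double bond or the longer chain goes with the higher number, a question that a saturated propyl group would address. Going by these compounds, on the chain, a primary amine or a dimethylamino group remains open with either methyl or allyl on the aromatic nitrogen.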